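Methyl in place of chloro: compound 2 to compound 4

This account rests on a few compounds, and the source may have more. Where it says the series, first, only, none or still open, it means among the compounds named here.

In a functional assay on DLD-1 cells (Homo sapiens) for inhibition, read by MTT assay, with a stated time of 72 h (on this read-out higher numbers stand for weaker inhibition and lower numbers for stronger inhibition), compound 2 `COc1cc(Oc2cccc(Nc3ccccc3)c2)cc(OC)c1CNCc1ccc(Cl)cc1` gives 3740 nM. Its nearest neighbour on this read-out is compound 1 `COc1cc(Oc2cccc(Nc3ccccc3)c2)cc(OC)c1CNCc1ccc(Br)cc1`, which in this assay gives 3520 nM; the step of a 1.1-fold higher number from compound 1 to compound 2 (0.03 log units; within the scatter) is within the scatter, so the two cannot be ordered against each other. Compound 3 `COc1cc(Oc2cccc(Nc3ccccc3)c2)cc(OC)c1CNC(C)C` reaches only the limit > 20000 nM in this assay, not a number. The limit of > 20000 nM in this assay, at which 1 of the 3 values shown sits, marks where compound 3 sits. The unmeasured compound 4 `COc1cc(Oc2cccc(Nc3ccccc3)c2)cc(OC)c1CNCc1ccc(C)cc1` differs from compound 2 in one place: methyl in place of chloro on an aromatic carbon. The step that bears most directly on this is a 1.1-fold higher number from compound 1 to compound 2 (0.03 log units; within the scatter), an exchange of one small group on the same aromatic carbon, which moved nothing beyond the scatter. The steps of an at least 5.6-fold higher number from compound 1 to compound 3 (0.75 log units; beyond the scatter) and an at least 5.3-fold higher number from compound 2 to compound 3 (0.72 log units; beyond the scatter) concern replacement of the whole 4-halobenzyl group by isopropyl and do not bear on an exchange that keeps the benzyl group. A further exchange of a single small group on that carbon is therefore expected to give a step of a 1.1-fold higher number from compound 2 to compound 4 (0.03 log units; within the scatter), not beyond the scatter. Compound 4 is expected to give 4000 nM in this assay, within 2000 nM to 8000 nM.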

Compound 4, half-maximal inhibitory concentration: 6080 nM
The estimate for compound 4 lay 1.5-fold (0.18 log units) below the measured number; low and high end bracket the measured number.
By their numbers in this assay, from the lowest: compounds 1, 2 and 4 (each within the scatter of the next). At a limit, above all of these: compound 3.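

In this assay, a carbon substituent on this aromatic carbon, para to a large group, stays within the scatter of both halogen compounds: a 1.6-fold higher number from compound 2 to compound 4 (0.21 log units; within the scatter), and a 1.7-fold higher number from compound 1 to compound 4 (0.24 log units; within the scatter). Chloro, bromo and methyl therefore cannot be separated at this position in this assay, so the exchange is tolerated beyond the halogens alone. The 4-methylbenzyl group also keeps the advantage over isopropyl on the amine nitrogen that the 4-halobenzyl groups showed, with an at least 3.2-fold lower number from compound 3 to compound 4 (0.51 log units; beyond the scatter). Compound 3 stands at a limit of the assay, not at a number: the limit of > 20000 nM in this assay, at which 1 of the 4 values shown sits.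

From the compounds shown here alone, whether a methoxy, an amine or a carboxylic acid on that carbon would move the number beyond the scatter remains open. So does the effect of an unsubstituted benzyl or a longer chain in that place.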